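The source may report more compounds than this note shows. Statements on the series, on what has been measured and on what is new or still open speak of the compounds shown alone.

In a functional assay on U-87MG ATCC cells for antiproliferative activity against U-87 MG (Homo sapiens), read by MTT assay, with a stated time of 48 h (a higher number here means a weaker inhibitor, a lower number a stronger inhibitor), compound 1 (`C/C(=C\CC/C(C)=C/CC[C@@H]1[C@@]2(C)CCC(=O)C(C)(C)[C@H]2CC[C@@]1(C)O)CC/C=C(\C)C(=O)OCc1cn(-c2cccc(Br)c2)nn1`) gives 8750000 nM as a measured number. Compound 2 (`C/C(=C\CC/C(C)=C/CC[C@@H]1[C@@]2(C)CCC(=O)C(C)(C)[C@H]2CC[C@@]1(C)O)CC/C=C(\C)C(=O)OCc1cn(-c2cccc(F)c2)nn1`) stands only at a limit of the assay, with > 150000 nM as that limit. Compound 3 (`C/C(=C\CC/C(C)=C/CC[C@@H]1[C@@]2(C)CCC(=O)C(C)(C)[C@H]2CC[C@@]1(C)O)CC/C=C(\C)C(=O)OCc1cn(-c2ccc(C(C)(C)C)cc2)nn1`) carries 4-(tert-butyl)phenyl in place of 3-fluorophenyl on an aromatic nitrogen. Within the data shown here, the one measured step that bears on this is a step that the limit leaves unreadable from compound 1 to compound 2 and so no size carries over from it. Among the measured compounds shown here, with compound 1 at 8750000 nM as the only number, weak inhibition is expected again in this assay with no firm direction. For compound 3 the expected value is 500000 nM ranging from 30000 nM to 9000000 nM by this estimate. The expected step is a step that the limit leaves unreadable from compound 2 to compound 3 and it remains only an estimate.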

Compound 3, half-maximal inhibitory concentration: > 150000 nM
Compound 3: a limit, no number; the forecaster's own chance of this, stated with the estimate: 45%; the middle value lies beyond the limit too.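

Among these compounds, compound 3 stands at a limit in this assay, not at a number, so no step from compound 1 or compound 2 to compound 3 can be read: the limit of > 150000 nM in this assay, at which 2 of the 3 values shown sit. Going by these compounds, how compound 2 and compound 3 compare in this assay stays open.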